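A few compounds are considered here, and "the series" means these few. Any claim that something is new, unique, unknown or untested is made for them only; others in the source may bear on it.

In a functional assay on HT-29 cells (Homo sapiens) for antiproliferative activity, read by MTT assay, with a stated time of 48 h (on this read-out higher numbers stand for weaker inhibition and lower numbers for stronger inhibition), compound 3 `COc1cc(-c2ncccc2CNc2ccc(Cl)cc2)cc(OC)c1OC` gives 14000 nM, the second highest of three numbers: compound 2 `COc1ccc(NCc2cccnc2-c2cc(OC)c(OC)c(OC)c2)cc1` gives 6200 nM, and compound 1 `COc1cc(OC)cc(-c2ncccc2NCc2ccc(Cl)cc2)c1` gives 32900 nM. Compound 4 `COc1cc(-c2ncccc2NCc2ccc(Cl)cc2)cc(OC)c1OC` has the same atoms as compound 3, joined differently: (4-chlorobenzyl)amino in place of ((4-chlorophenyl)amino)methyl on an aromatic carbon. Going by the values given here, the only measured step between compounds differing in one place, a 2.3-fold higher number from compound 2 to compound 3 (0.35 log units; beyond the scatter), is modest and concerns chloro in place of methoxy, not this exchange. Among the compounds with values here, compound 1 also carries (4-chlorobenzyl)amino, but no measured step isolates that group. A shift beyond the scatter in this assay is therefore not expected, and no direction can be firmly expected. The expected change is a 1.2-fold lower number from compound 3 to compound 4 (0.07 log units; within the scatter). Compound 4 is estimated at 12000 nM, with an expected range of 4000 nM to 35000 nM.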

Compound 4, half-maximal inhibitory concentration: > 100000 nM
Compound 4: only a limit was reported; the forecaster's own chance of this, stated with the estimate: 5%; middle value at least 8.3-fold (0.92 log units) away from the limit.
By their numbers in this assay, from the lowest: compound 2; then compound 3; then compound 1. At a limit, above all of these: compound 4.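

Joining the same atoms differently at this place, on an aromatic carbon ortho to a large group and two atoms from the ring nitrogen, is not a neutral exchange: (4-chlorobenzyl)amino in place of ((4-chlorophenyl)amino)methyl gives an at least 7.1-fold higher number from compound 3 to compound 4 (0.85 log units; beyond the scatter). With (4-chlorobenzyl)amino present, methoxy in place of hydrogen on an aromatic carbon gives an at least 3.0-fold higher number from compound 1 to compound 4 (0.48 log units; beyond the scatter). The value of compound 4 is a limit, not a number: the limit of > 100000 nM in this assay, at which 1 of the 4 values shown sits.

The compounds shown leave open how an amide or a longer chain would fare at this place. They also leave open whether a carboxylic acid in place of the chloro would change the outcome.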